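A few compounds are considered here, and "the series" means these few. Any claim that something is new, unique, unknown or untested is made for them only; others in the source may bear on it.

Of the compounds shown here, two have been tested in a functional assay, with a stated time of 10 min; a lower number here means a stronger inhibitor, a higher number a weaker inhibitor. Compound 1, `CCOC(=O)c1cnn(-c2nc(-c3ccccc3Cl)c(C#N)c(=O)n2C)c1N`, gives 98 ug/mL in this assay, which places it as the weaker of the two. Compound 2, `COc1cccc(-c2nc(SC)n(C)c(=O)c2C#N)c1OC`, gives 43 ug/mL in this assay, a lower number and so a stronger inhibitor than compound 1; the gap between them lies beyond the usual scatter. Compound 3, `CCOC(=O)c1cnn(-c2nc(-c3cccc(O)c3O)c(C#N)c(=O)n2C)c1N`, has not yet been measured. It differs from compound 1 in one place: 2,3-dihydroxyphenyl in place of 2-chlorophenyl on an aromatic carbon. Going by the values given here, no step between measured compounds shows what this change does in this assay, so any expectation rests on compound 1 alone and on the size of the change. With nothing to point firmly in either direction, the step of a 1.4-fold lower number from compound 1 to compound 3 (0.15 log units; within the scatter) is expected to be small, within or close to the scatter, with the number perhaps edging lower. Compound 3 is therefore estimated at 70 ug/mL in this assay, with a range from 25 ug/mL to 200 ug/mL.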

Compound 3, half-maximal inhibitory concentration: 53 ug/mL
Beside the measured number, compound 3's estimate is 1.3-fold (0.12 log units) above it; the range from low to high includes it.
By their numbers in this assay, from the lowest: compounds 2, 3 and 1 (each within the scatter of the next, the first and the last beyond it).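

Putting 2,3-dihydroxyphenyl in place of 2-chlorophenyl on this aromatic carbon gives, in this assay, a 1.8-fold lower number from compound 1 to compound 3 (0.27 log units; within the scatter). This first step at the position shows that a phenyl ring without chlorine, carrying hydrogen-bond donors and acceptors that 2-chlorophenyl lacks, leaves the number within the scatter, so this pair shows no clear gain or loss. No measurement at hand explains this result.

A single step cannot tell whether either hydroxyl group matters on its own, or whether a plain phenyl ring would read the same. Also open, as far as these compounds go, is how this assay would respond to an amine or a carboxylic acid on that phenyl ring, or to a longer chain in place of the ring.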